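Bromine on a Shared Core: Expecting Seizure Protection

This account rests on a few compounds, and the source may have more. Where it says the series, first, only, none or still open, it means among the compounds named here.

Three close relatives have been measured. Compound 1 `Cc1nc2ccccc2c(=O)n1NCc1nnc(/N=C/c2ccc(N(C)C)cc2)s1`, compound 2 `Cc1nc2ccc(Br)cc2c(=O)n1NCc1nnc(/N=C/c2ccc(N(C)C)cc2)s1` and compound 3 `Cc1nc2ccccc2c(=O)n1NCc1nnc(/N=C/c2ccc(O)cc2)s1` were each tested in a functional assay on the whole organism (strain albino) with Rattus norvegicus as the target, in the maximal electroshock model, with a stated time of 1 h, at a dose of 30 mg/kg by the intraperitoneal route; a higher number here means more inhibition at the dose given (going by the name of the read-out), a lower number less inhibition. Compound 1 gives 50%, compound 2 gives 50% and compound 3 gives 50%. Compound 2 differs from compound 1 by bromo in place of hydrogen on an aromatic carbon, and that step shows no change at the digits printed from compound 1 to compound 2 (within the scatter). The cores of compound 1 and compound 3 differ by hydroxy in place of dimethylamino on an aromatic carbon, with no change at the digits printed from compound 1 to compound 3 (within the scatter). Compound 4 `Cc1nc2ccc(Br)cc2c(=O)n1NCc1nnc(/N=C/c2ccc(O)cc2)s1` has not yet been measured; it differs from compound 3 by bromo in place of hydrogen on an aromatic carbon, the same change as that made from compound 1 to compound 2, here on the core of compound 3. Because no change at the digits printed from compound 1 to compound 2 (within the scatter), the step of no change at the digits printed from compound 3 to compound 4 (within the scatter) is expected to be equally small. Compound 4 is therefore estimated at 50% in this assay, likely between 38% and 62%.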

Compound 4, a percentage reported as inhibition, in the whole organism at one dose (the size of the read-out at that dose, not a potency): 50%
The estimate for compound 4 equals the measured number at the digits printed; low and high end bracket the measured number.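

In this assay, bromo in place of hydrogen shows no change at the digits printed from compound 3 to compound 4 (within the scatter), and hydroxy in place of dimethylamino shows no change at the digits printed from compound 2 to compound 4 (within the scatter); neither result says anything about potency, since a reading at one dose is not a potency, or about a change that does shift the read-out. The bromo step reads alike on both cores: the same change on two cores in this assay, no change at the digits printed (within the scatter) from compound 1 to compound 2 and no change at the digits printed (within the scatter) from compound 3 to compound 4, 0 percentage points apart, within the scatter of two such steps. The hydroxy step also reads alike on both cores: the same change on two cores in this assay, no change at the digits printed (within the scatter) from compound 1 to compound 3 and no change at the digits printed (within the scatter) from compound 2 to compound 4, 0 percentage points apart, within the scatter of two such steps.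

The compounds shown leave open whether chloro or methoxy in place of bromo would give a different figure. They also leave open what a carboxylic acid in place of hydroxy, or a longer chain in place of the methyl on the shared core, would do.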